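A Methoxy Group Added to Compound 1

The compounds below may be only part of what the source reports. "The series", "measured", "known", "first", "only" and "open" are said of these compounds alone.

In a functional assay on K562 cells (Homo sapiens) for inhibition, read by sulforhodamine B assay, with a stated time of 48 h (a higher number here means a weaker inhibitor of growth, a lower number a stronger inhibitor of growth), compound 1 `S=C(N/N=C/c1cccs1)Nc1ccccc1` gives 16700 nM while compound 2 `S=C(N/N=C/c1cccs1)Nc1cccnc1` stands level with it at 16400 nM and compound 3 `S=C(N/N=C/c1cccs1)Nc1cccc2ccccc12` reads 1800 nM at the strong end of the three. Compound 1 thus sits at the weak end, together with compound 2. The change methoxy in place of hydrogen on an aromatic carbon puts methoxy in place of hydrogen on an aromatic carbon, para to a large group, and turns compound 1 into compound 4 `COc1ccc(NC(=S)N/N=C/c2cccs2)cc1`. For the measured compounds named here, no measured pair isolates this change, so in this assay only a small step toward stronger inhibition of growth is expected, possibly none beyond the scatter. Compound 4 is estimated at 10000 nM with an expected range from 4000 nM to 25000 nM in this measurement. The expected step is a 1.7-fold lower number from compound 1 to compound 4 (0.22 log units; within the scatter) as estimated here.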

Compound 4, concentration for 50% growth inhibition: 1700 nM
For compound 4 the middle estimate is 5.9-fold (0.77 log units) above the measured one; the measured number lies below the stated range.
By their numbers in this assay, from the lowest: compounds 4 and 3 (each within the scatter of the next); then compounds 2 and 1 (each within the scatter of the next).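

For the compounds shown here, the single change of methoxy in place of hydrogen, on an aromatic carbon para to a large group, gives a 9.8-fold lower number from compound 1 to compound 4 (0.99 log units; beyond the scatter) in this assay. Going by these compounds alone, this is the first isolated change, and it shows that this position of the six-membered aromatic ring of carbon only responds to substitution, with a step beyond the scatter. Nothing available explains the size of this step.

As far as these compounds go, it remains open whether a hydroxyl, an amine or a longer chain such as ethoxy at this position would give a similar step. A single methoxy group also cannot show whether the response depends on the oxygen or on the added carbon.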